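A few compounds are considered here, and "the series" means these few. Any claim that something is new, unique, unknown or untested is made for them only; others in the source may bear on it.

In a toxicity assay on MDCK cells (Canis lupus familiaris) for cytotoxicity, read by CCK-8 assay, with a stated time of 48 h (a lower number here means that less compound is tolerated, a higher number that more compound is tolerated), compound 1 (`O=C(NNc1c(Br)cccc1Br)c1ccc(F)cc1`) reaches only a limit, > 100000 nM. Compound 2 (`O=C(NNc1c(Br)cccc1Br)c1ccccc1`) also reaches only a limit, > 100000 nM. Among the measured compounds shown here, compound 3 (`CCN(CC)c1ccc(C(=O)NNc2c(Br)cccc2Br)cc1`) gives the only actual number, 34000 nM, so it is the least tolerated of the three. Compound 4 (`O=C(O)c1ccc(C(=O)NNc2c(Br)cccc2Br)cc1`) differs from compound 3 as follows: carboxy in place of diethylamino on an aromatic carbon. For the measured compounds named here, no measured step involves carboxy, so the closest guides are the two steps that brought in diethylamino, an at least 2.9-fold lower number from compound 1 to compound 3 (0.46 log units; beyond the scatter) and an at least 2.9-fold lower number from compound 2 to compound 3 (0.46 log units; beyond the scatter). With diethylamino gone from compound 4, those steps suggest that the number should climb back by a similar amount or more. The expected step is a 3.2-fold higher number from compound 3 to compound 4 (0.51 log units; beyond the scatter). Compound 4 is estimated at 110000 nM, within an expected range of 50000 nM to 300000 nM.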

Compound 4, half-maximal cytotoxic concentration: > 100000 nM
Compound 4 gave a limit, no number; the forecaster's own chance of this, stated with the estimate: 65%; the middle value does not contradict the limit.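

Putting carboxy in place of diethylamino on this aromatic carbon gives an at least 2.9-fold higher number from compound 3 to compound 4 (0.46 log units; beyond the scatter) in this assay. Of the four groups shown at this position, only diethylamino brings the number down from the limit, so the lower number of compound 3 depends on that group rather than on any replacement of hydrogen. The steps from compound 1 and compound 2 to compound 4 cannot be read, because all three values stop at a limit: the limit of > 100000 nM in this assay, at which 3 of the 4 values shown sit. Going by these compounds, whether a smaller amine such as dimethylamino, or a longer chain such as butyl, also lowers the number remains open.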